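Adding a Methyl Group to the Compound with the Lowest Number

A few compounds are considered here, and "the series" means these few. Any claim that something is new, unique, unknown or untested is made for them only; others in the source may bear on it.

Compound 1 `COc1ccc(Cl)c(-c2nnc3sc(-c4ccnc(Cl)c4)nn23)c1`: 14.4%
Compound 2 `COc1ccc2[nH]cc(Cc3nn4c(Cc5ccc(OC)c(OC)c5)nnc4s3)c2c1`: 4.11%
Compound 3 `COc1ccc2[nH]cc(Cc3nn4c(-c5ccoc5C)nnc4s3)c2c1`: 16%

In a functional assay on the whole organism (strain Wistar Albino) for inhibition, with Rattus norvegicus as the target, read by paw edema, with a stated time of 1 h, at a dose of 20 mg/kg (on this read-out lower numbers stand for less inhibition and higher numbers for more inhibition at the one dose given (going by the name of the read-out)), compound 2 gives 4.11%, the lowest of the three numbers. Compound 1 gives 14.4% and compound 3 gives 16%, and both lie beyond the scatter above compound 2. Compound 4 `COc1ccc2[nH]c(C)c(Cc3nn4c(Cc5ccc(OC)c(OC)c5)nnc4s3)c2c1` has not been measured. It differs from compound 2 in one place: methyl in place of hydrogen on an aromatic carbon. The methyl sits on an aromatic carbon of the five-membered aromatic ring, next to the ring nitrogen. Going by the values given here, no two measured compounds differ in a single place, so these numbers give no guide to the size of such a step. A single added carbon is expected to give no step beyond the scatter, in either direction. Compound 4 is estimated at 9%, between 0% and 22%, an expected step of a number 4.9 percentage points higher from compound 2 to compound 4 (within the scatter).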

Compound 4, a percentage reported as inhibition, in the whole organism at one dose (the size of the read-out at that dose, not a potency): 10.5%
Beside the measured number, compound 4's estimate is 1.5 percentage points below it, and the stated range covers the measured number.
By their numbers in this assay, from the lowest: compounds 2, 4, 1 and 3 (each within the scatter of the next, the first and the last beyond it).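

Going by these compounds alone, this is the first single change that can be read: with methyl in place of hydrogen on an aromatic carbon, next to the ring nitrogen, this assay shows a number 6.4 percentage points higher from compound 2 to compound 4 (within the scatter). At this position and this one dose, the added carbon therefore leaves the read-out within the usual scatter, and the number stays low in either compound.

From the compounds shown here alone, whether an ethyl group or an amine at the same place would give a step beyond the scatter stays open. Nothing measured here gives a reason for this result.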